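This account rests on a few compounds, and the source may have more. Where it says the series, first, only, none or still open, it means among the compounds named here.

Measured so far in a toxicity assay on MDCK cells (Canis lupus familiaris) for cytotoxicity, read by crystal violet staining, with a stated time of 48 h; a lower number here means that less compound is tolerated, a higher number that more compound is tolerated:
compound 1 `CCc1ccc2[nH]c(=O)c(CN(Cc3ccc(C(C)(C)C)cc3)[C@@H](C)c3ccc(OC)cc3)cc2c1`: > 5000 nM, a limit
compound 2 `COc1ccc([C@H](C)N(Cc2ccc(C(C)(C)C)cc2)Cc2cc3cc(OC)ccc3[nH]c2=O)cc1`: 4100 nM
compound 3 `CC(C)c1ccc2[nH]c(=O)c(CN(Cc3ccc(C(C)(C)C)cc3)C(C)c3ccc(N(C)C)c(Cl)c3)cc2c1`: > 10000 nM, a limit

Compound 3 stands only at a limit in this assay, namely (the limit of > 10000 nM in this assay, at which 1 of the 3 values shown sits), with no number attached. Compound 4 `COc1ccc([C@H](C)N(Cc2ccc(C(C)(C)C)cc2)Cc2cc3cc(C(C)C)ccc3[nH]c2=O)cc1` differs from compound 3 by 1-(4-methoxyphenyl)ethyl in place of 1-(3-chloro-4-(dimethylamino)phenyl)ethyl on an amine nitrogen. Among the measured compounds shown here, no measured step samples that exchange on the amine nitrogen; the only measured step, an at least 1.2-fold lower number from compound 1 to compound 2 (0.08 log units; that floor lies within the scatter), changes the core and stays within the scatter. Compound 1 also sits at a limit, (the limit of > 5000 nM in this assay, at which 1 of the 3 values shown sits). The same group on the amine nitrogen as in compound 4 is carried by compound 2, which gives 4100 nM. Compound 4 is therefore expected near that, estimated at 6000 nM, range 2500 nM to 15000 nM, with a fair chance of only a limit; the expected step of an at least 1.6-fold lower number from compound 3 to compound 4 (0.22 log units; that floor lies within the scatter) is uncertain because compound 3 gives (the limit of > 10000 nM in this assay, at which 1 of the 3 values shown sits).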

Compound 4, half-maximal cytotoxic concentration: > 10000 nM
Compound 4 gave a limit, no number; the forecaster's own chance of this, stated with the estimate: 50%; at least 1.6-fold (0.22 log units) between middle value and limit.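

In this assay, among the compounds shown here, isopropyl in place of methoxy on an aromatic carbon gives an at least 2.4-fold higher number from compound 2 to compound 4 (0.38 log units; beyond the scatter), the first step beyond the scatter, so the group at this place on the shared core does shift the tolerated concentration. The steps from compound 3 to compound 4 and from compound 1 to compound 4 cannot be read, with limits at both ends. Compound 3 and compound 4 share one limit: the limit of > 10000 nM in this assay, at which 2 of the 4 values shown sit.

Going by these compounds, with only compound 2 giving a number, the true size of this step stays open. Also open, on these data alone, is what an amine or a carboxylic acid at that aromatic carbon would give.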